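Swapping an Acetoxyethyl Ester Chain for an Oxolane Ring

This account rests on a few compounds, and the source may have more. Where it says the series, first, only, none or still open, it means among the compounds named here.

Compound 1 `CC(C)=CC[C@@H](OC[C@@H](C)O)C1=CC(=O)c2c(O)ccc(O)c2C1=O`: 14300 nM
Compound 2 `CC(=O)OCCC(=O)O[C@H](CC=C(C)C)C1=CC(=O)c2c(O)ccc(O)c2C1=O`: 15700 nM
Compound 3 `CCCC(CC(=O)O[C@H](CC=C(C)C)C1=CC(=O)c2c(O)ccc(O)c2C1=O)OC(C)=O`: 55700 nM

In a functional assay on DU-145 cells (Homo sapiens) for cytotoxicity, read by MTT assay (a lower number here means a stronger inhibitor, a higher number a weaker inhibitor), compound 2 stands second highest of the three numbers, within the scatter of compound 1 and separated only from compound 3. Compound 4 `CC(C)=CC[C@@H](OC(=O)C1CCOC1)C1=CC(=O)c2c(O)ccc(O)c2C1=O` differs from compound 2 by oxolan-3-yl in place of 2-acetoxyethyl on a carbonyl carbon. Going by the values given here, no measured step exchanges this group directly. The two steps that bear on the same region are a 1.1-fold higher number from compound 1 to compound 2 (0.04 log units; within the scatter), which lies within the scatter, and a 3.5-fold higher number from compound 2 to compound 3 (0.55 log units; beyond the scatter), a modest loss when a propyl is added further along the chain. Since the change here removes the chain rather than extending it, compound 4 is expected to show a step of a 1.0-fold higher number from compound 2 to compound 4 (0.01 log units; within the scatter), none beyond the scatter. Compound 4 is therefore estimated at 16000 nM, with a range from 7000 nM to 40000 nM.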

Compound 4, half-maximal inhibitory concentration: 47500 nM
For compound 4 the middle estimate is 3.0-fold (0.47 log units) below the measured one, outside the stated range (above it).
By their numbers in this assay, from the lowest: compounds 1 and 2 (each within the scatter of the next); then compounds 4 and 3 (each within the scatter of the next).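

In this assay, oxolan-3-yl on the carbonyl carbon is not an interchangeable replacement for 2-acetoxyethyl, giving a 3.0-fold higher number from compound 2 to compound 4 (0.48 log units; beyond the scatter) and, against the 2-hydroxypropyl ether, a 3.3-fold higher number from compound 1 to compound 4 (0.52 log units; beyond the scatter). Adding propyl was thus not the only change here to move the number beyond the scatter, and the ring instead leaves compound 4 level with the longer chain, at a 1.2-fold lower number from compound 3 to compound 4 (0.07 log units; within the scatter). No measurement offered here explains this step. What the compounds shown leave open is whether a cyclopentyl ring or a chain ending in an amine at this carbonyl carbon would stay with compound 2 or with compound 4.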